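Aryl urea variation on the shared core, step to compound 4

The source may hold more compounds than are shown below. What is called first, only, known or untested is meant among the compounds shown, and "the series" means these compounds.

Three measured members share the core of compound 1 `COc1cc2c(Oc3ccc(/C=N/NC(=O)Nc4ccccc4)cc3F)ccnc2cc1OCCCN1CCCCC1` and differ only in the aryl group on the urea. In a functional assay on HT-29 cells (Homo sapiens) for cytotoxicity, read by MTT assay, with a stated time of 72 h (on this read-out lower numbers stand for stronger inhibition and higher numbers for weaker inhibition), compound 1 gives 190 nM. Compound 2 `COc1cc2c(Oc3ccc(/C=N/NC(=O)Nc4ccc(F)c(F)c4)cc3F)ccnc2cc1OCCCN1CCCCC1` gives 490 nM in this assay, and compound 3 `COc1cc2c(Oc3ccc(/C=N/NC(=O)Nc4ccc(Br)cc4)cc3F)ccnc2cc1OCCCN1CCCCC1` gives 270 nM. Compound 3 therefore sits second highest of the three numbers, with compound 1 nearest and compound 2 furthest; both of its gaps are within the scatter, so no order among them can be claimed.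

Compound 4 `COc1cc2c(Oc3ccc(/C=N/NC(=O)Nc4ccc(F)cc4Br)cc3F)ccnc2cc1OCCCN1CCCCC1` is not yet measured. It differs from compound 3 in one place: 2-bromo-4-fluorophenyl in place of 4-bromophenyl on an amide-type nitrogen. For the measured compounds named here, two measured steps bear on this. The step of a 1.4-fold higher number from compound 1 to compound 3 (0.15 log units; within the scatter) shows that bromo in place of hydrogen on the aromatic carbon changed little. The step of a 2.6-fold higher number from compound 1 to compound 2 (0.41 log units; beyond the scatter) shows that adding fluorine to the phenyl gave a modestly higher number, while a 1.8-fold lower number from compound 2 to compound 3 (0.26 log units; within the scatter) was within the scatter. Compound 4 carries both a bromine and a fluorine on the ring, so a small rise in the number is expected, at most a modest one, with a step of a 1.4-fold higher number from compound 3 to compound 4 (0.15 log units; within the scatter) estimated. Compound 4 is expected to give 380 nM in this assay, within a range of 150 nM to 950 nM.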

Compound 4, half-maximal inhibitory concentration: 110 nM
The estimate for compound 4 lay 3.5-fold (0.54 log units) above the measured number; measured number outside the range, below it.
By their numbers in this assay, from the lowest: compounds 4, 1, 3 and 2 (each within the scatter of the next, the first and the last beyond it).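

In this assay the aryl group on the amide-type nitrogen now gives a lower number beyond the scatter, since 2-bromo-4-fluorophenyl in place of 4-bromophenyl gives a 2.5-fold lower number from compound 3 to compound 4 (0.39 log units; beyond the scatter) and in place of 3,4-difluorophenyl gives a 4.5-fold lower number from compound 2 to compound 4 (0.65 log units; beyond the scatter) on the same core. A ring carrying fluorine therefore does not go with a higher number in every case: compound 2 and compound 4 both carry it and sit well apart, so the pattern suggested by compound 2 alone does not hold for compound 4. Against plain phenyl the new group gives a 1.7-fold lower number from compound 1 to compound 4 (0.24 log units; within the scatter) and so is not separated from compound 1, which means that no aryl group shown so far has moved the number beyond the scatter in the lower direction from that parent. No measurement at hand accounts for any of these differences.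

A 2-bromophenyl or a 4-fluorophenyl group on the same nitrogen would show which halogen of the new group goes with the step from compound 3. On these data alone, how a methoxy, a trifluoromethyl or a dimethylamino group on this ring would read remains open, as does whether the same order would hold in any other cell line.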